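Triazole methyl removal in a fluoroindazole pyridinone series

A few compounds are considered here, and "the series" means these few. Any claim that something is new, unique, unknown or untested is made for them only; others in the source may bear on it.

Measured so far in a physicochemical assay for solubility, in phosphate buffer, measured as kinetic solubility; a higher number here means a more soluble compound, a lower number a less soluble compound:
compound 1, `CCn1ncc2c(F)cc(-c3ccc(C(CC)(CC)c4nnc(C)[nH]4)c(=O)[nH]3)cc21`: 26900 nM
compound 2, `CC(C)C(c1ccc(-c2ccc3cccc(F)c3c2)[nH]c1=O)N1CCNC1=O`: 24900 nM
compound 3, `CC(C)C(/C=C1\CCNC1=O)c1ccc(-c2ccc3cccc(F)c3c2)[nH]c1=O`: 20700 nM

Compound 1 sits with the other two within the usual scatter: compound 2 lies within scatter of it, and so does compound 3. Among the measured compounds shown here, the one measured step, a 1.2-fold lower number from compound 2 to compound 3 (0.08 log units; within the scatter), concerns a ring swap on a different scaffold and is itself within the scatter, so it does not bear on the change at hand.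

Compound 4, `CCn1ncc2c(F)cc(-c3ccc(C(CC)(CC)c4nnc[nH]4)c(=O)[nH]3)cc21`, differs from compound 1 only by hydrogen in place of methyl on an aromatic carbon. For the measured compounds named here, no measured step tests this change; a shift beyond the scatter is not expected in this assay. Compound 4 is estimated at 25000 nM, ranging from 12000 nM to 50000 nM. This estimate amounts to a 1.1-fold lower number from compound 1 to compound 4 (0.03 log units; within the scatter).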

Compound 4, solubility: 35500 nM
Beside the measured number, compound 4's estimate is 1.4-fold (0.15 log units) below it, and the stated range covers the measured number.
By their numbers in this assay, from the lowest: compounds 3, 2, 1 and 4 (each within the scatter of the next).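

In this assay, going from 5-methyl-4H-1,2,4-triazol-3-yl to 4H-1,2,4-triazol-3-yl gives a 1.3-fold higher number from compound 1 to compound 4 (0.12 log units; within the scatter). Among the compounds shown here, this is the first direct reading of this position: on this aromatic carbon of the triazole, hydrogen in place of methyl leaves the read-out within the scatter, in this one pair. No evidence on hand bears on this result.

From the compounds shown here alone, whether an amine, a carboxylic acid or a longer chain such as ethyl on the same carbon would also stay within the scatter remains open.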